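From 1,3-Oxazol-2-yl to Pyridin-3-yl: Expected Lipophilicity

A few compounds are considered here, and "the series" means these few. Any claim that something is new, unique, unknown or untested is made for them only; others in the source may bear on it.

Three compounds have been measured so far in a physicochemical assay for lipophilicity, using the shake flask method, in phosphate buffer, measured as octanol-water partition, with a stated time of 30 min, at pH 7.4; a lower number here means a more polar compound, a higher number a more lipophilic compound:
Compound 1, `Cn1cc(-c2cnc(NCc3c(F)ccc4c3CCO4)c3cn[nH]c(=O)c23)cn1`, gives 2.7.
Compound 2, `CN(c1ncco1)c1cnc(NCc2c(F)ccc3c2CCO3)n2cnnc12`, gives 2.1.
Compound 3, `Cn1nccc1-c1cnc(NCc2c(F)ccc3c2CCO3)c2cn[nH]c(=O)c12`, gives 2.6.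

Compound 2 stands lowest of these three numbers, and both gaps to it lie beyond the scatter: compound 3 is nearest, and compound 1 furthest. Between compound 1 and compound 3 the only difference is 1-methyl-1H-pyrazol-5-yl in place of 1-methyl-1H-pyrazol-4-yl on an aromatic carbon, and that step, a number 0.10 log units lower from compound 1 to compound 3 (within the scatter), stays within the scatter.

The next compound, compound 4, is `CN(c1cccnc1)c1cnc(NCc2c(F)ccc3c2CCO3)n2cnnc12`. Compared with compound 2 it carries the following change:
pyridin-3-yl in place of 1,3-oxazol-2-yl on a nitrogen on an aromatic ring

Within the data shown here, none of the measured steps touches this part of the molecule, and no pair among the three measured compounds differs in the group on this nitrogen, so nothing measured here bears directly on the change. The move from a five-membered ring with two hetero atoms and two hydrogen-bond acceptors to a six-membered ring with one hetero atom and one acceptor, with one more heavy atom, is expected to push the number upward in this assay by a step beyond the scatter, a number 0.50 log units higher from compound 2 to compound 4 (beyond the scatter). On that basis compound 4 is estimated at 2.6, with a range from 2.2 to 3.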

Compound 4, distribution coefficient: 2.6
Compound 4: the middle estimate sits on the measured number at the digits printed; low and high end bracket the measured number.
By their numbers in this assay, from the lowest: compound 2; then compounds 3, 4 and 1 (each within the scatter of the next).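

In this assay, this nitrogen proves to be a place where the measured number can move: swapping 1,3-oxazol-2-yl for pyridin-3-yl gives a number 0.50 log units higher from compound 2 to compound 4 (beyond the scatter). Among these compounds, the only earlier step, which moved a ring attachment point in a different part of the molecule, was a number 0.10 log units lower from compound 1 to compound 3 (within the scatter), so this is the first step in the set to lie beyond the scatter. The swap changes several things at once, from a five-membered aromatic ring with 2 hetero atoms and 2 hydrogen-bond acceptors to a six-membered aromatic ring with 1 hetero atom and 1 hydrogen-bond acceptor, and no measurement available here explains the step or ties it to any one of those changes.

With only these two groups on this nitrogen, the compounds shown cannot separate the effect of ring size from that of the ring atoms. They also leave open where the number would fall with a plain phenyl ring, a pyridin-2-yl ring or a carboxylic acid-bearing group in the same place.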